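Phenyl to 4-methylphenyl on compound 1: an expectation

This account rests on a few compounds, and the source may have more. Where it says the series, first, only, none or still open, it means among the compounds named here.

Measured so far in an assay on MDA-MB-231 cells for binding affinity to C-X-C chemokine receptor type 4 (Homo sapiens), read by immunofluorescence and microscopy, with stated times of 10 min and 30 min; on this read-out higher numbers stand for an effect only at larger amounts of compound and lower numbers for an effect already at smaller amounts:
compound 1 `O=C(NCc1ccc(CNS(=O)(=O)c2ccccc2)cc1)c1cccnc1`: 10 nM
compound 2 `O=C(NCc1ccc(CNS(=O)(=O)c2ccccc2)cc1)c1cccc(Cl)c1`: 1000 nM
compound 3 `O=C(NCc1ccc(CNS(=O)(=O)c2ccccc2)cc1)c1ccccc1Cl`: 10 nM

Compound 1 stands level with compound 3, the two together lowest of the three; their step is no change at the digits printed from compound 1 to compound 3 (within the scatter). Compound 2 lies furthest off, with a 100-fold higher number from compound 1 to compound 2 (2.00 log units; beyond the scatter), and a 100-fold lower number from compound 2 to compound 3 (2.00 log units; beyond the scatter) closes the triangle. All three measured steps vary the group on the carbonyl carbon only.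

Compound 4 `Cc1ccc(S(=O)(=O)NCc2ccc(CNC(=O)c3cccnc3)cc2)cc1` differs from compound 1 by methyl in place of hydrogen on an aromatic carbon. For the measured compounds named here, no measured step touches that part of the shared core, so none bears directly on this change; the small size of what enters gives no ground for a large move. The expected outcome in this assay is no change at the digits printed from compound 1 to compound 4 (within the scatter). Compound 4 is estimated at 10 nM, within 3 nM to 40 nM.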

Compound 4, effective concentration (reported as EC, without a stated level of effect): > 1000 nM
Compound 4 ended at the assay's limit; the forecaster's own chance of this, stated with the estimate: 5%; middle value at least 100-fold (2.00 log units) from the limit.
By their numbers in this assay, from the lowest: compounds 1 and 3 (each within the scatter of the next); then compound 2.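

Methyl in place of hydrogen gives an at least 100-fold higher number from compound 1 to compound 4 (2.00 log units; beyond the scatter), a step that rests on a limit and not on a number. The earlier steps shown here varied only the group on the carbonyl carbon; this one shows that the phenyl of compound 1 is also sensitive to change, even to a single added carbon. How far compound 4 lies past that limit stays unknown: the limit of > 1000 nM in this assay, at which 1 of the 4 values shown sits.

From the compounds shown here alone, whether a fluorine atom or a methoxy group on the same aromatic carbon would do the same remains open. So does whether methyl has this effect on compound 3.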